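This account rests on a few compounds, and the source may have more. Where it says the series, first, only, none or still open, it means among the compounds named here.

Measured so far:
compound 1 `CCCCc1cn(C(c2ccccc2)c2cc3cc(Br)ccc3nc2OC)nn1` — 5.46%
compound 2 `CCCCCCCCc1cn(C(c2ccccc2)c2cc3cc(Br)ccc3nc2OC)nn1` — 12.1%

In an ADME assay on PANC-1 cells (Homo sapiens) for cytotoxicity, read by sulforhodamine B assay, with a stated time of 48 h, tested at 10 uM (on this read-out higher numbers stand for more inhibition at the one concentration tested (going by the name of the read-out) and lower numbers for less inhibition), compound 1 gives 5.46%; compound 2 gives 12.1%, and the step of a number 6.6 percentage points higher from compound 1 to compound 2 (within the scatter) keeps both at one level, so compound 1 stands together with compound 2 within the scatter. Compound 3 `CCCc1cn(C(c2ccccc2)c2cc3cc(Br)ccc3nc2OC)nn1` differs from compound 1 by hydrogen in place of methyl on a saturated chain carbon, three bonds along the chain from an aromatic carbon. Going by the values given here, the only measured step alters the same chain the other way and stays within the scatter, so no step beyond the scatter is expected here either. Compound 3 is therefore estimated at 4%, range -5% to 13%. The expected step is a number 1.5 percentage points lower from compound 1 to compound 3 (within the scatter).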

Compound 3, a percentage reported as inhibition, at one concentration (the size of the read-out at that concentration, not a potency): 11.3%
Beside the measured number, compound 3's estimate is 7.3 percentage points below it, and the stated range covers the measured number.
By their numbers in this assay, from the lowest: compounds 1, 3 and 2 (each within the scatter of the next).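

At the saturated chain carbon, hydrogen in place of methyl gives a number 5.8 percentage points higher from compound 1 to compound 3 (within the scatter) in this assay, and hydrogen in place of pentyl gives a number 0.8 percentage points lower from compound 2 to compound 3 (within the scatter) on the same read-out. Propyl thus joins butyl and octyl at one level on the shared core, so neither a one-carbon nor a five-carbon difference in this chain gives a step beyond the scatter. Nothing available bears on why these values stand together.

On these data alone, whether an amine or a carboxylic acid in place of the alkyl chain would give a step beyond the scatter stays open.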